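From 3-fluoro-4-methoxyphenyl to 2,5-difluorophenyl

The compounds below may be only part of what the source reports. "The series", "measured", "known", "first", "only" and "open" are said of these compounds alone.

Of the compounds shown here, two sharing one core have so far been tested in a functional assay on A549 cells (Homo sapiens) for antiproliferative activity, read by MTT assay, with a stated time of 72 h; a higher number here means a weaker inhibitor, a lower number a stronger inhibitor. Compound 1 (`COc1cc(-n2cnc3ccc(-c4ccccc4Cl)cc32)cc(OC)c1OC`) gives > 10000 nM, which is a limit of the assay and not a number.

Among the compounds with values here, compound 2 (`COc1ccc(-c2ccc3ncn(-c4cc(OC)c(OC)c(OC)c4)c3c2)cc1F`) gives 1430 nM, the only true number available. Within the data shown here, the one measured step, an at least 6.9-fold lower number from compound 1 to compound 2 (0.84 log units; beyond the scatter), came with 3-fluoro-4-methoxyphenyl in place of 2-chlorophenyl.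

Compound 3 (`COc1cc(-n2cnc3ccc(-c4cc(F)ccc4F)cc32)cc(OC)c1OC`) keeps the core but carries 2,5-difluorophenyl in place of 3-fluoro-4-methoxyphenyl on an aromatic carbon. Its new ring bears only halogen, as the ring of compound 1 does, and the methoxy group of compound 2 is gone. Among the measured compounds shown here, this change therefore looks like a partial return towards compound 1, and the step of an at least 6.9-fold lower number from compound 1 to compound 2 (0.84 log units; beyond the scatter) is the only guide to it. A move to a higher number in this assay, meaning a weaker inhibitor, is expected, though one step gives little basis for its size.

The estimated change is a 3.5-fold higher number from compound 2 to compound 3 (0.54 log units; beyond the scatter). For compound 3, the expected value is 5000 nM, with an estimated range of 1800 nM to 14000 nM.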

Compound 3, half-maximal inhibitory concentration: 7940 nM
Compound 3: middle estimate off by 1.6-fold (0.20 log units), on the low side; the range from low to high includes it.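

In this assay, placing 2,5-difluorophenyl where 3-fluoro-4-methoxyphenyl stood gave a 5.6-fold higher number from compound 2 to compound 3 (0.74 log units; beyond the scatter), so the ring at this position can move the number in either direction, and the gain seen in compound 2 does not carry over to every new ring. Within the data shown here, compound 1 and compound 3, whose rings bear only halogen, both lie on the weaker side of compound 2, the one compound here with a methoxy group on that ring, although three compounds make this an observation and not a rule. Compound 1 stands at a limit of the assay and not at a number, so the comparison of the two halogen-bearing rings reads only as an at least 1.2-fold lower number from compound 1 to compound 3 (0.10 log units; that floor lies within the scatter), which does not separate them: the limit of > 10000 nM in this assay, at which 1 of the 3 values shown sits.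

On these data alone, what remains open is which feature of the ring in compound 2 goes with its lower number: the methoxy group, the fluorine or the way the two are arranged. As far as these compounds go, how a plain methoxyphenyl, or a ring bearing an amine or a carboxylic acid, would fare at this position also remains open.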